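Adding a Chloro to the Core of Compound 1

This account rests on a few compounds, and the source may have more. Where it says the series, first, only, none or still open, it means among the compounds named here.

Compound 1 `ClCc1ccc(Cn2cnc3c(Cl)ncnc32)cc1` has no result in a functional assay on SW-620 cells (Homo sapiens) for cytotoxicity, read by sulforhodamine B assay, with a stated time of 48 h; a higher number here means a weaker inhibitor of growth, a lower number a stronger inhibitor of growth; its entry there reads "not determined" (no result reported), so it gives no number to stand on. Two relatives do: compound 2 `ClCc1cccc(Cn2cnc3c(Cl)nc(Cl)nc32)c1` gives 3460 nM in this assay, and compound 3 `ClCc1ccccc1Cn1cnc2nc(Cl)nc(Cl)c21` gives 670 nM. Both carry the same core that compound 4 `ClCc1ccc(Cn2cnc3c(Cl)nc(Cl)nc32)cc1` would carry. Compound 4 differs from compound 1 by chloro in place of hydrogen on an aromatic carbon. For the measured compounds named here, with no number for compound 1, no step in this assay can be sized or given a direction; the expectation rests on compounds 2 and 3 alone, whose values lie well apart. Compound 4 is therefore expected to land between them, at about 1500 nM, with a likely range from 400 nM to 6000 nM.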

Compound 4, concentration for total growth inhibition: 17400 nM
Compound 4: middle estimate off by 12-fold (1.06 log units), on the low side; measured number above the stated range.
By their numbers in this assay, from the lowest: compound 3; then compound 2; then compound 4.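

No step can be read between compound 1 and compound 4 in this assay. The compounds shown leave open what the chloro in place of hydrogen does to growth inhibition. Nothing given here offers an explanation for the value of compound 4.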